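The compounds below may be only part of what the source reports. "The series", "measured", "known", "first", "only" and "open" are said of these compounds alone.

Measured in a functional assay on MIA PaCa-2 cells (Homo sapiens) for inhibition, read by MTT assay, with a stated time of 7 days; on this read-out higher numbers stand for weaker inhibition and lower numbers for stronger inhibition:
- compound 1 `CCCN(CCC)S(=O)(=O)c1ccc(S(=O)(=O)N2CCC[C@@H](C(=O)OCC)C2)cc1`: 2300 nM
- compound 2 `CCN(CC)C(=O)[C@@H]1CCCN(S(=O)(=O)c2ccc(S(=O)(=O)N(CC)CC)cc2)C1`: 6400 nM

Compound 1 at 2300 nM holds the lower of the two numbers and so the stronger inhibition. Compound 2 at 6400 nM lies higher, a gap beyond the scatter. Among the measured compounds shown here, these two compounds differ in more than one place, so no measured step isolates a single change.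

Next in line is compound 3 `CCOC(=O)[C@@H]1CCCN(S(=O)(=O)c2ccc(S(=O)(=O)N(C)Cc3ccccc3)cc2)C1`, which carries benzyl(methyl)amino in place of dipropylamino on a sulfonyl sulfur. For the measured compounds named here, with no direct precedent, only a small shift in this assay is expected, with none beyond the scatter and no firm direction. The expected step is a 1.3-fold higher number from compound 1 to compound 3 (0.12 log units; within the scatter), which leaves the number close to that of the starting compound. For compound 3 the estimated value is 3000 nM, with an expected range from 1000 nM to 9000 nM and the measurement still to come.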

Compound 3, half-maximal inhibitory concentration: > 30000 nM
Compound 3 gave a limit, no number; the forecaster's own chance of this, stated with the estimate: 5%; at least 10-fold (1.00 log units) between middle value and limit.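

In this assay, the sulfonyl sulfur whose other neighbours are aromatic carbon proves to be a sensitive place in the series: benzyl(methyl)amino in place of dipropylamino gives an at least 13-fold higher number from compound 1 to compound 3 (1.11 log units; beyond the scatter). Among the compounds shown here, the reading for compound 3 is a limit of the assay and not a number: the limit of > 30000 nM in this assay, at which 1 of the 3 values shown sits. This is the first step that changes one place only, whereas compound 1 and compound 2 differ in more than one place and could not isolate this position.

The compounds shown do not separate the entering aromatic ring from the loss of the propyl chains, so cyclohexyl(methyl)amino and dibutylamino on the same sulfur remain open comparisons. Also open, on these data alone, is whether this sulfur tolerates any ring-bearing amine, such as piperidine, on the core of compound 1.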